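Half-life limits and an aryl swap in the series

The source may report more compounds than this note shows. Statements on the series, on what has been measured and on what is new or still open speak of the compounds shown alone.

Measured in an ADME assay on microsomes from liver (Rattus norvegicus) for metabolic stability, read by LC-MS, using NADPH, at 37 degrees C; a higher number here means that the compound lasts longer, a lower number that the compound disappears faster:
compound 1 `Cc1cc(C)c(-c2nc(CN3CCC(C(=O)NCCCN4C[C@H](C)C[C@H](C)C4)CC3)c(C)o2)c(C)c1`: > 0.5 h
compound 2 `Cc1ccccc1-c1nc(CN2CCC(C(=O)NCCCN3CCC(C)CC3)CC2)c(C)o1`: > 0.5 h
compound 3 `Cc1ccccc1-c1nc(CN2CCC(C(=O)NCCCN3[C@H](C)CCC[C@@H]3C)CC2)c(C)o1`: > 0.5 h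

Each of these entries is a limit of the assay and not a number. Going by the values given here, the series so far gives no measured half-life, and the evidence is a single shared reading: the limit of > 0.5 h in this assay, at which 3 of the 3 values shown sit.

Compound 1 stands at > 0.5 h in this assay, which is a limit only.

The next compound is compound 4 `Cc1oc(-c2ccc(Cl)c(Cl)c2)nc1CN1CCC(C(=O)NCCCN2C[C@H](C)C[C@H](C)C2)CC1`, and its difference from compound 1 is 3,4-dichlorophenyl in place of 2,4,6-trimethylphenyl on an aromatic carbon. In short, 3,4-dichlorophenyl stands in place of 2,4,6-trimethylphenyl on an aromatic carbon.

Among the compounds with values here, only one measured step exists, a step that the two limits leave unreadable from compound 2 to compound 3. It concerns a different place in the molecule, and its size cannot be read. Within the data shown here, no measured step therefore covers the change at the aromatic carbon, and the data give no direction for it.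

The expectation rests on compound 1 at > 0.5 h and on the shared limit (the limit of > 0.5 h in this assay, at which 3 of the 3 values shown sit). No step beyond the scatter is expected, and compound 4 may well be reported as a limit too. The expected step is a step that the limit leaves unreadable from compound 1 to compound 4.

For compound 4 the estimate is 0.6 h, with an expected range from 0.3 h to 1.2 h.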

Compound 4, half-life: > 0.5 h
Compound 4 was reported as a limit; the forecaster's own chance of this, stated with the estimate: 65%; the middle value is on the limit's open side.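

In this assay compound 4 gives > 0.5 h, a limit of the assay and not a number. Compound 1 also stands at a limit, so no step can be read between compound 1 and compound 4. The compounds shown leave open what any actual half-life is, and whether 3,4-dichlorophenyl in place of 2,4,6-trimethylphenyl changes it.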